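The source may report more compounds than this note shows. Statements on the series, on what has been measured and on what is new or still open speak of the compounds shown alone.

Compound 1 `CCN(CC#Cc1ccccc1N=[N+]=[N-])Cc1cccc(OCc2cc(-c3ccsc3)cs2)c1` — in an assay (Sus scrofa) for inhibition of squalene monooxygenase (Homo sapiens), using microsomes (on this read-out higher numbers stand for weaker inhibition and lower numbers for stronger inhibition), compound 1 gives > 100000 nM, which is a limit of the assay and not a number.
Compound 2 `CCN(CC#Cc1cccc(N=[N+]=[N-])c1)Cc1cccc(OCc2cc(-c3ccsc3)cs2)c1` — in this assay compound 2 gives 270 nM.

Within the data shown here, compound 2 stands as the only compound of the pair with an actual number in this assay; the other value is a limit, as the limit of > 100000 nM in this assay, at which 1 of the 2 values shown sits, notes. Compound 3 `CCN(CC#Cc1ccc(N=[N+]=[N-])cc1)Cc1cccc(OCc2cc(-c3ccsc3)cs2)c1` differs from compound 2 in one place: 4-azidophenyl in place of 3-azidophenyl on a triple-bonded carbon. Among the measured compounds shown here, the only measured step that bears on moving the azide around this ring is an at least 370-fold lower number from compound 1 to compound 2 (2.56 log units; beyond the scatter), a large shift that shows the placement of the azido group can move the read-out far beyond the scatter. For the measured compounds named here, no measured step covers the 4-azidophenyl arrangement, so the direction of the step is open, and a shift in either direction beyond the scatter cannot be ruled out. Compound 3 is expected to give about 600 nM, within a wide range of 100 nM to 8000 nM. The expected step from compound 2 to compound 3 in this assay is therefore a 2.2-fold higher number from compound 2 to compound 3 (0.35 log units; beyond the scatter), with low confidence.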

Compound 3, half-maximal inhibitory concentration: 960 nM
The estimate for compound 3 lay 1.6-fold (0.20 log units) below the measured number; the range from low to high includes it.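

In this assay, the azido group's placement matters even among the arrangements that give a number: a 3.6-fold higher number from compound 2 to compound 3 (0.55 log units; beyond the scatter), a modest step set against the large one already seen for 2-azidophenyl. The further step, an at least 100-fold lower number from compound 1 to compound 3 (2.01 log units; beyond the scatter), shows that 4-azidophenyl also keeps far stronger inhibition than 2-azidophenyl, so among these three compounds the 2-azidophenyl arrangement stands apart and compound 2 reads lowest. The value for compound 1 is a limit of the assay and not a number, so both large steps give only a bound: the limit of > 100000 nM in this assay, at which 1 of the 3 values shown sits.

As far as these compounds go, how an unsubstituted phenyl or a 4-methoxyphenyl on the triple-bonded carbon would read remains open. So does whether the azido group itself adds to or takes from the inhibition seen with compound 2 and compound 3.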